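The source may report more compounds than this note shows. Statements on the series, on what has been measured and on what is new or still open speak of the compounds shown alone.

Measured so far:
compound 1, `Cc1cc(S(=O)(=O)/N=C(\N)n2nccc2-c2ccccc2)c(SCc2cccc(Cl)c2)cc1Cl`: 10000 nM
compound 2, `Cc1cc(-c2ccccc2)n(/C(N)=N/S(=O)(=O)c2cc(C)c(Cl)cc2SCc2cccc(C(F)(F)F)c2)n1`: 40000 nM

In an ADME assay on HaCaT cells (Homo sapiens) for cytotoxicity, read by MTT assay, with a stated time of 72 h (a lower number here means a stronger inhibitor, a higher number a weaker inhibitor), compound 1 gives 10000 nM, the lowest number of the two shown. Compound 2 gives 40000 nM, a gap beyond the scatter, and nothing more can be said of that pair. Compound 3, `Cc1cc(S(=O)(=O)/N=C(\N)n2nccc2-c2ccccc2)c(SCc2ccc(Cl)cc2)cc1Cl`, is not yet measured. It differs from compound 1 by 4-chlorophenyl in place of 3-chlorophenyl on a saturated chain carbon bound to a sulfur. Within the data shown here, no step of this kind is known among the measured compounds, so compound 3 is expected to sit close to compound 1, with a step of a 1.2-fold higher number from compound 1 to compound 3 (0.08 log units; within the scatter) that is expected to stay within the scatter. Compound 3 is estimated at 12000 nM, between 5000 nM and 30000 nM.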

Compound 3, half-maximal inhibitory concentration: 12000 nM
For compound 3 middle estimate and measured number coincide at the digits printed; the range from low to high includes it.
By their numbers in this assay, from the lowest: compounds 1 and 3 (each within the scatter of the next); then compound 2.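

In this assay, among these compounds, the change from 3-chlorobenzyl to 4-chlorobenzyl gives a 1.2-fold higher number from compound 1 to compound 3 (0.08 log units; within the scatter) and is the first single-place comparison. At this saturated chain carbon bound to a sulfur, the two chlorophenyl groups are not told apart by this read-out. No supporting data bear on this result.

Still open, going by these compounds, is whether a plain phenyl, a methoxyphenyl or a pyridine ring at this place would stay as close to compound 1. The effect of a trifluoromethyl group at this place also remains unresolved, as compound 2 differs from compound 1 in more than one place.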